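The compounds below may be only part of what the source reports. "The series", "measured", "known", "first", "only" and "open" are said of these compounds alone.

Two compounds built on the shared core of compound 1 `CN(CC(C)(C)C)CC1(O)CCN(CCCc2c[nH]c3ccc(-n4cnnc4)cc23)CC1` have been tested in a functional assay on CHO cells for agonist activity at 5-hydroxytryptamine receptor 1D (Homo sapiens), read by GTPgammaS binding; on this read-out higher numbers stand for an effect only at larger amounts of compound and lower numbers for an effect already at smaller amounts. Compound 1 gives 1.6 nM, while compound 2 `CC(C)(C)OC(=O)NCC1(O)CCN(CCCc2c[nH]c3ccc(-n4cnnc4)cc23)CC1` gives 9.7 nM. For the measured compounds named here, compound 2 thus holds the higher of the two numbers, with compound 1 the nearest neighbour below it; the single step between them is a 6.1-fold higher number from compound 1 to compound 2 (0.78 log units; beyond the scatter), and it is the only comparison available. Compound 3 `CN(CC1CCCCC1)CC1(O)CCN(CCCc2c[nH]c3ccc(-n4cnnc4)cc23)CC1` has not yet been measured. Its difference from compound 2 is (cyclohexylmethyl)(methyl)amino in place of (tert-butoxycarbonyl)amino on a saturated chain carbon bound to a saturated ring carbon. This returns the chain to a tertiary amine of the kind found in compound 1, with a cyclohexylmethyl group where compound 1 carries a neopentyl group. The step from compound 1 to compound 2 therefore bears directly on the question, since it ran the opposite way: a change from a tertiary amine to the carbamate raised the number by a modest amount, so the return to a tertiary amine is expected to lower it by a step of about the same size. Compound 3 is accordingly expected to give 2 nM, between 0.7 nM and 6 nM, an expected step of a 4.9-fold lower number from compound 2 to compound 3 (0.69 log units; beyond the scatter).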

Compound 3, concentration for half-maximal effect: 1.4 nM
Compound 3: middle estimate off by 1.4-fold (0.15 log units), on the high side; the measured number falls inside the stated range.
By their numbers in this assay, from the lowest: compounds 3 and 1 (each within the scatter of the next); then compound 2.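

In this assay, the return from (tert-butoxycarbonyl)amino to a tertiary amine, here (cyclohexylmethyl)(methyl)amino on a saturated chain carbon bound to a saturated ring carbon, gives a 6.9-fold lower number from compound 2 to compound 3 (0.84 log units; beyond the scatter), so the earlier gap to the carbamate is now seen with a second amine and not only with methyl(neopentyl)amino. Cyclohexyl in place of tert-butyl on a saturated chain carbon bound to an amine nitrogen gives a 1.1-fold lower number from compound 1 to compound 3 (0.06 log units; within the scatter), which means that, of the two groups tried on this amine, neither can be told from the other in this assay. For the compounds shown here, the three compounds thus fall into two sets, the two tertiary amines together and the carbamate of compound 2 apart from them, and no compound among them goes against this split.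

From the compounds shown here alone, whether an aromatic benzyl group in place of the cyclohexylmethyl, a secondary amine without the methyl, or a simple amide on the same chain carbon would keep the number at the level of the two tertiary amines remains open. Nothing measured on these compounds gives a reason for either step.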